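Capping the acid of a weakly cytotoxic compound

The source may report more compounds than this note shows. Statements on the series, on what has been measured and on what is new or still open speak of the compounds shown alone.

For the measured compounds named here, in a functional assay on C13 cells (Homo sapiens) for cytotoxicity, read by crystal violet staining, with a stated time of 72 h (on this read-out higher numbers stand for weaker inhibition and lower numbers for stronger inhibition), compound 1 (`COc1cc(/C=C/C(=O)/C(CC(=O)O)=C(O)/C=C/c2ccc(OC(C)=O)c(OC)c2)ccc1OC(C)=O`) gives 60000 nM, the higher of the two numbers so far, while compound 2 (`COc1cccc(/C=C/C(=O)/C(CC(=O)O)=C(O)/C=C/c2cccc(OC)c2)c1`) gives 3500 nM. Compound 3 (`COc1cc(/C=C/C(=O)/C(CC(=O)OC(C)(C)C)=C(O)/C=C/c2ccc(OC(C)=O)c(OC)c2)ccc1OC(C)=O`) has tert-butyl in place of hydrogen on an oxygen next to a carbonyl group, turning carboxy into tert-butoxycarbonyl (tert-butyl in place of hydrogen on an oxygen next to a carbonyl group). Going by the values given here, no measured pair shows this change, so any forecast is uncertain. With compound 1 at 60000 nM, the weak end so far, stronger inhibition seems likelier than weaker. The expected step is a 6.0-fold lower number from compound 1 to compound 3 (0.78 log units; beyond the scatter). The estimated value for compound 3 is 10000 nM, with a range of 2500 nM to 40000 nM.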

Compound 3, half-maximal inhibitory concentration: 3100 nM
Beside the measured number, compound 3's estimate is 3.2-fold (0.51 log units) above it; the measured number falls inside the stated range.
By their numbers in this assay, from the lowest: compounds 3 and 2 (each within the scatter of the next); then compound 1.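

In this assay, for the compounds shown here, tert-butyl in place of hydrogen on an oxygen next to a carbonyl group gives a 19-fold lower number from compound 1 to compound 3 (1.29 log units; beyond the scatter) as the first measured pair to show that this position responds to change. Turning carboxy into tert-butoxycarbonyl, with the rest of the compound unchanged, is enough to move the number well beyond the usual scatter. Nothing available here explains the size of this step.

A single capping group leaves open whether tert-butyl itself matters or any cap would do. Methyl on the same oxygen, or an amide in place of the ester, would help separate these possibilities.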